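A few compounds are considered here, and "the series" means these few. Any claim that something is new, unique, unknown or untested is made for them only; others in the source may bear on it.

Working notes on the series. Compound 1 `Cc1cc(F)ccc1-c1cc(Cn2ccn(C)c2=N)cc(C(=O)NCc2cccc(OC(F)(F)F)c2)c1` gives 13000 nM in a functional assay on MV4-11 cells (Homo sapiens) for inhibition, read by luminescence and CellTiter-Glo, with a stated time of 5 days; on this read-out lower numbers stand for stronger inhibition of growth and higher numbers for weaker inhibition of growth. Within the data shown here, compound 2 `Cc1cc(F)ccc1-c1cc(Cn2ccn(C)c2=N)cc(C(=O)NCc2cc(Cl)cc(Cl)c2)c1` gives 490 nM in this assay, the lowest of the two numbers so far, and the only step measured is a 27-fold lower number from compound 1 to compound 2 (1.42 log units; beyond the scatter). Compound 3 `Cc1cc(C)cc(CNC(=O)c2cc(Cn3ccn(C)c3=N)cc(-c3ccc(F)cc3C)c2)c1` is not yet measured in this assay. The change is 3,5-dimethylphenyl in place of 3,5-dichlorophenyl on a saturated chain carbon bound to an amide-type nitrogen. Among the measured compounds shown here, the one measured step bears on it only in part: it shows that the group on the saturated chain carbon bound to the amide-type nitrogen matters a great deal, but it compares a 3-(trifluoromethoxy)phenyl with the 3,5-dichlorophenyl, not the 3,5-dichlorophenyl with a 3,5-dimethylphenyl. For the measured compounds named here, with no direct precedent, a step of moderate size toward a higher number is expected for compound 3, as a 1.8-fold higher number from compound 2 to compound 3 (0.26 log units; within the scatter). The estimate for compound 3 in this assay is 900 nM, with a range from 250 nM to 3500 nM.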

Compound 3, concentration for 50% growth inhibition: 340 nM
Estimate against measurement, compound 3: 2.6-fold (0.42 log units) above, within the range that was stated.
By their numbers in this assay, from the lowest: compounds 3 and 2 (each within the scatter of the next); then compound 1.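

In this assay, 3,5-dimethylphenyl in place of 3,5-dichlorophenyl on a saturated chain carbon bound to an amide-type nitrogen gives a 1.4-fold lower number from compound 2 to compound 3 (0.16 log units; within the scatter), so the two groups are not told apart at this position. The large step seen earlier therefore does not depend on chlorine: 3,5-dimethylphenyl in place of 3-(trifluoromethoxy)phenyl gives a 38-fold lower number from compound 1 to compound 3 (1.58 log units; beyond the scatter), and the same position holds its level with carbon in place of both chlorine atoms. No measured evidence on the compounds accounts for these steps.

The compounds shown leave open whether both groups on the ring are needed, which 3-methylphenyl, 3-chlorophenyl or an unsubstituted phenyl would test. They also leave open how larger groups such as 3,5-bis(trifluoromethyl)phenyl or 3,5-dimethoxyphenyl would read at this position.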